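Swapping Methanesulfonamido for Azido in a Stable Series

The compounds below may be only part of what the source reports. "The series", "measured", "known", "first", "only" and "open" are said of these compounds alone.

Compound 1 `COc1ccc(-c2c(C)nc3c(N4CC[C@@H](NC(C)=O)C4)cc(C)nn23)cc1F` and compound 2 `COc1ccc(-c2c(C)nc3c(N4CC[C@@H](NS(C)(=O)=O)C4)cc(C)nn23)cc1OC` were both examined in an ADME assay on microsomes from liver (Mus musculus) for metabolic stability, read by LC-MS, with NADPH named in the record, with a stated time of 60 min, tested at 1 uM, in the absence of a further agent; on this read-out higher numbers stand for a more stable compound and lower numbers for a less stable compound. In this assay compound 1 gives > 95%, a limit of the assay rather than a number. In this assay compound 2 likewise reaches > 95%, which is also a limit. Within the data shown here, compound 2 thus stands at the ceiling of what the assay can report, together with the one other value shown (the limit of > 95% in this assay, at which 2 of the 2 values shown sit). Compound 3 `COc1ccc(-c2c(C)nc3c(N4CC[C@@H](N=[N+]=[N-])C4)cc(C)nn23)cc1OC` has not yet been measured. It differs from compound 2 in one place: azido in place of methanesulfonamido on a saturated ring carbon. Among the measured compounds shown here, no measured pair here differs in a single place, so no measured step is available to lean on. Compound 3 is expected to remain near the ceiling, and the step of a number at least 3 percentage points lower from compound 2 to compound 3 (that floor lies within the scatter) is expected to be none beyond the scatter. The estimate for compound 3 in this assay is 92%, between 78% and 99%.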

Compound 3, percent of the compound remaining: > 95%
Compound 3 ended at the assay's limit; the forecaster's own chance of this, stated with the estimate: 55%; middle value at least 3 percentage points from the limit.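

No step from compound 2 to compound 3 can be read in this assay, since both compounds sit at a limit of the assay: the limit of > 95% in this assay, at which 3 of the 3 values shown sit.

The compounds shown leave open whether azido and methanesulfonamido differ at all on this read-out, as none gives a value inside the assay's range.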